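A few compounds are considered here, and "the series" means these few. Any claim that something is new, unique, unknown or untested is made for them only; others in the source may bear on it.

Of the compounds shown here, three built on one shared core have so far been tested in a functional assay on the whole organism (strain Kunming) with Mus musculus as the target, in the maximal electroshock model, with a stated time of 0.5 h; a lower number here means that less compound is needed, a higher number that more compound is needed for the effect. Compound 1 `Cc1ccc(N2C(=O)NC3(CC3c3ccc4cccc(OCc5ccccc5)c4n3)C2=O)cc1` carries a 4-methylphenyl group on an amide-type nitrogen in a ring, and in this assay compound 1 gives 100 mg/kg, the lowest of the three numbers. Compound 2 `O=C1NC2(CC2c2ccc3cccc(OCc4ccccc4)c3n2)C(=O)N1C1CCCCC1` has a cyclohexyl group in that place, and in this assay compound 2 gives 300 mg/kg. Compound 3 `O=C1NC(=O)C2(CC2c2ccc3cccc(OCc4ccccc4)c3n2)N1` has only a hydrogen there, and in this assay compound 3 gives 300 mg/kg. Both replacements move the number in the same direction: a 3.0-fold higher number from compound 1 to compound 2 (0.48 log units; beyond the scatter) and a 3.0-fold higher number from compound 1 to compound 3 (0.48 log units; beyond the scatter), while between the two replacements themselves there is no change at the digits printed from compound 2 to compound 3 (within the scatter).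

Compound 4 `CCCCN1C(=O)NC2(CC2c2ccc3cccc(OCc4ccccc4)c3n2)C1=O` is not yet measured. It differs from compound 1 in one place: butyl in place of 4-methylphenyl on an amide-type nitrogen in a ring. The two measured steps bear directly on this change, since each swaps the 4-methylphenyl on that nitrogen for something else, and each raised the number by a modest amount, as seen in a 3.0-fold higher number from compound 1 to compound 2 (0.48 log units; beyond the scatter) and a 3.0-fold higher number from compound 1 to compound 3 (0.48 log units; beyond the scatter). A butyl chain in that place is therefore expected to behave like the cyclohexyl or the hydrogen rather than like the 4-methylphenyl, giving an expected step of a 3.0-fold higher number from compound 1 to compound 4 (0.48 log units; beyond the scatter). Compound 4 is thus estimated to give 300 mg/kg in this assay, with a likely range from 100 mg/kg to 600 mg/kg.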

Compound 4, minimum effective dose: 300 mg/kg
The estimate for compound 4 equals the measured number at the digits printed, within the range that was stated.
By their numbers in this assay, from the lowest: compound 1; then compounds 2, 3 and 4 (each within the scatter of the next).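

In this assay, butyl brings an open chain with no ring onto the amide-type nitrogen, and the change gives a 3.0-fold higher number from compound 1 to compound 4 (0.48 log units; beyond the scatter) in a step as large as those to the cyclohexyl and hydrogen compounds. The chain is not separated from the other two replacements, as shown by no change at the digits printed from compound 3 to compound 4 (within the scatter) and by no change at the digits printed from compound 2 to compound 4 (within the scatter), so hydrogen, cyclohexyl and butyl cannot be told apart here, and among these four compounds only the 4-methylphenyl of compound 1 stands apart, with none going against this pattern. Nothing measured here accounts for the gap between the 4-methylphenyl group and the other three groups.

The compounds shown leave open whether the lower number goes with the aromatic ring itself or with its methyl group, a question that plain phenyl or 4-methoxyphenyl on the same nitrogen would address. They also leave open whether a benzyl group, with one carbon set between the nitrogen and the ring, would match compound 1 or the other three compounds.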